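The source may report more compounds than this note shows. Statements on the series, on what has been measured and on what is new or still open speak of the compounds shown alone.

Measured compounds in a functional assay on Raji cells (Homo sapiens) for antiproliferative activity, read by CCK-8 assay, with a stated time of 72 h, tested at 40 uM; a lower number here means less inhibition, a higher number more inhibition at the concentration tested (going by the name of the read-out):

Compound 1 `CN1CCN(c2ccc(Nc3nc(-c4cccc(NC(=O)c5cccc(F)c5)c4)sc3C(=O)O)cc2)CC1` gives 76.3%.
Compound 2 `CN1CCN(c2ccc(Nc3nc(-c4cccc(NC(=O)c5ccccc5F)c4)sc3C(=O)O)cc2)CC1` gives 86.9%.
Compound 3 `CN1CCN(c2ccc(Nc3nc(-c4cccc(NC(=O)c5ccc(Cl)cc5)c4)sc3C(=O)O)cc2)CC1` gives 90.9%.

Compound 3 holds the highest of the three numbers in this assay. Its margin over compound 2 is a number 4 percentage points higher from compound 2 to compound 3 (within the scatter), which sits inside the scatter, so the two cannot be ranked; its margin over compound 1 is a number 14.6 percentage points higher from compound 1 to compound 3 (beyond the scatter), which is beyond the scatter. All three differ only in the phenyl on the carbonyl carbon of the amide.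

Compound 4 `CN1CCN(c2ccc(Nc3nc(-c4cccc(NC(=O)c5ccc(F)c(Cl)c5)c4)sc3C(=O)O)cc2)CC1` is not yet measured. Against compound 3 the change is 3-chloro-4-fluorophenyl in place of 4-chlorophenyl on a carbonyl carbon. The steps that touch the same place are the exchanges of halophenyl groups among compounds 1, 2 and 3: a number 10.6 percentage points higher from compound 1 to compound 2 (beyond the scatter), a number 14.6 percentage points higher from compound 1 to compound 3 (beyond the scatter) and a number 4 percentage points higher from compound 2 to compound 3 (within the scatter). Both groups that carry a halogen in the position shared with compound 4 ended within the scatter of each other, and the whole spread across the three compounds is modest. Since the entering group keeps the chlorine of compound 3 and adds only a fluorine, no step beyond the scatter is expected in this assay.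

Compound 4 is therefore expected at about 90%, with a range of 80% to 97%. The expected step from compound 3 is a number 0.9 percentage points lower from compound 3 to compound 4 (within the scatter).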

Compound 4, a percentage reported as inhibition, at one concentration (the size of the read-out at that concentration, not a potency): 87.9%
For compound 4 the middle estimate is 2.1 percentage points above the measured one; the range from low to high includes it.
By their numbers in this assay, from the lowest: compound 1; then compounds 2, 4 and 3 (each within the scatter of the next).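

In this assay, the 3-chloro-4-fluorophenyl group on the carbonyl carbon gives a number 3 percentage points lower from compound 3 to compound 4 (within the scatter) and a number 1 percentage points higher from compound 2 to compound 4 (within the scatter), so a phenyl carrying two halogens fits in with the singly halogenated groups of compound 2 and compound 3, with no readable change. Going by these compounds alone, the step of a number 11.6 percentage points higher from compound 1 to compound 4 (beyond the scatter) leaves compound 1, with its 3-fluorophenyl group, as the only compound beyond the scatter of all the others, and since compound 4 also carries a halogen in its 3-chloro substituent, a halogen at that ring position does not by itself go with the lower number. Nothing available accounts for the gap between compound 1 and the other three, or for the closeness of those three.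

Going by these compounds, all four groups are halogenated phenyls, so it remains open whether this position holds its numbers with a methoxy, a nitrile or a dimethylamino group on the phenyl, or with a cyclohexyl in place of the phenyl. Compounds 2, 3 and 4 also stay unranked at this single concentration, and whether they would separate on a full concentration-response curve is an open question.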